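The compounds below may be only part of what the source reports. "The series", "measured", "known", "first", "only" and "open" are said of these compounds alone.

Measured in a functional assay for agonist activity at growth hormone secretagogue receptor type 1 (Homo sapiens), read by FLIPR; on this read-out lower numbers stand for an effect already at smaller amounts and higher numbers for an effect only at larger amounts of compound:
compound 1 `C[C@@H]1CN(c2ccc(Cl)c(NS(=O)(=O)c3ccc(-c4ccccn4)s3)c2)C[C@H](C)N1` gives 39.8 nM
compound 2 `COc1ccc(N2C[C@@H](C)N[C@@H](C)C2)cc1NS(=O)(=O)c1ccc(-c2ccccc2)cc1` gives 6.31 nM
compound 3 `COc1ccc(N2C[C@@H](C)N[C@@H](C)C2)cc1NS(=O)(=O)c1cccc(-c2ccco2)c1` gives 20 nM

Compound 2 holds the lowest number of the three in this assay; its gaps to compound 3 and to compound 1 both lie beyond the usual scatter of this read-out. Compound 4 `COc1ccc(N2C[C@@H](C)N[C@@H](C)C2)cc1NS(=O)(=O)c1ccc(Oc2ccccc2)cc1` differs from compound 2 in a single place: phenoxy in place of phenyl on an aromatic carbon. Among the measured compounds shown here, no measured pair carries this same change, so its size is not anchored by any known step. The step of a 1.9-fold higher number from compound 2 to compound 4 (0.28 log units; within the scatter) is expected to be small, probably within the scatter or a modest move toward a higher number. Compound 4 is accordingly estimated at 12 nM, with a range from 3.5 nM to 40 nM.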

Compound 4, half-maximal effective concentration: 63.1 nM
Compound 4: the middle estimate sits 5.3-fold (0.72 log units) below what was measured; measured number above the stated range.
By their numbers in this assay, from the lowest: compound 2; then compounds 3, 1 and 4 (each within the scatter of the next, the first and the last beyond it).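

In this assay, among the compounds shown here, the phenyl of compound 2 sits on an aromatic carbon para to a large group, and phenoxy there brings a 10-fold higher number from compound 2 to compound 4 (1.00 log units; beyond the scatter), the first one-place comparison. The same carbon-only aromatic ring remains, so this position is not indifferent to the oxygen that phenoxy inserts. No available measurement gives a cause for this step.

Open, as far as these compounds go, is how benzyloxy, benzyl or anilino would read at this position, and whether phenoxy gives a comparable step on the chloro compound or on other sulfonamide aryl groups.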